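Fluorophenyl and trifluoromethylphenyl piperazine succinimides in electroshock

This account rests on a few compounds, and the source may have more. Where it says the series, first, only, none or still open, it means among the compounds named here.

Measured compounds:
compound 1, `CCC(C(=O)N1CCN(c2ccc(F)cc2)CC1)N1C(=O)CCC1=O`: 25%
compound 2, `CC(C(=O)N1CCN(c2ccc(F)cc2)CC1)N1C(=O)CCC1=O`: 25%
compound 3, `CC(C(=O)N1CCN(c2ccccc2C(F)(F)F)CC1)N1C(=O)CCC1=O`: 75%

All three were run in a functional assay on the whole organism (strain Swiss) with Mus musculus as the target, in the maximal electroshock model, with a stated time of 1 h, at a dose of 300 mg/kg by the intraperitoneal route; on this read-out lower numbers stand for a weaker effect and higher numbers for a stronger effect at the one dose given. Compound 3 gives the highest number of the set; in this assay compound 1 and compound 2 both sit well below it, and the gap from either to compound 3 is beyond the scatter.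

Compound 1 and compound 2 share one core and differ by a single change, (methyl in place of hydrogen on a saturated chain carbon, two bonds along the chain from an amide-type nitrogen in a ring and a carbonyl carbon). The step that goes with it is no change at the digits printed from compound 2 to compound 1 (within the scatter).

Compound 3 carries a different core from compound 2; the difference between the two cores is not broken down here.

The unmeasured compound 4, `CCC(C(=O)N1CCN(c2ccccc2C(F)(F)F)CC1)N1C(=O)CCC1=O`, is compound 3 with the same change applied: methyl in place of hydrogen on a saturated chain carbon, two bonds along the chain from an amide-type nitrogen in a ring and a carbonyl carbon. The place of the change is the same in both pairs, so this is the same change, now on the core of compound 3 rather than on that of compound 2.

For the measured compounds named here, for compound 4 in this assay, a step of about no change at the digits printed from compound 3 to compound 4 (within the scatter) is expected, because no change at the digits printed from compound 2 to compound 1 (within the scatter) and nothing among the measured compounds shows this change behaving otherwise. Going by the values given here, only one earlier instance of the change exists, and it sits on a different core, so the expectation is held loosely. Compound 4 is accordingly estimated at 75%, with a range from 50% to 100%.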

Compound 4, a percentage reported as activity, at one dose (the size of the read-out at that dose, not a potency): 0%
Compound 4: the middle estimate sits 75 percentage points above what was measured, and the stated range ends above it.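

Placed on the second core in this assay, the change of hydrogen to methyl on a saturated chain carbon, which reads equally as methyl to ethyl, gives a number 75 percentage points lower from compound 3 to compound 4 (beyond the scatter). On the two cores shown, the earlier result for this change therefore does not carry over, and its effect depends on the core it sits on: the same change on two cores in this assay, no change at the digits printed (within the scatter) from compound 2 to compound 1 and a number 75 percentage points lower (beyond the scatter) from compound 3 to compound 4, 75 percentage points apart, beyond the scatter of two such steps. This rests on one pair per core and on a single dose and time, so it shows no potency shift and no general rule for the series, and it does not tell which feature of the two cores separates the outcomes, as the difference between them is not broken down here.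

Open, as far as these compounds go, is whether a longer chain at the same carbon, such as propyl, or a polar group there, such as a hydroxyl or an amine, would follow the flat step on the first core or the large drop on the second. Also open, from the compounds shown here alone, is how the same change behaves on a core with another group on the aromatic ring, such as chlorine or methoxy, which would help show where along that range of cores the behaviour of the change turns.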